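Ortho substituent changes on the aryl ether of the shared core

This account rests on a few compounds, and the source may have more. Where it says the series, first, only, none or still open, it means among the compounds named here.

Three compounds on the shared core carry different groups on the aryl ether ring. In an in vitro assay on HEK293 cells for inhibition of sodium-dependent dopamine transporter (Homo sapiens) (on this read-out higher numbers stand for weaker inhibition and lower numbers for stronger inhibition), compound 1 `CNC[C@]1(O)Cc2ccccc2[C@@H]1Oc1ccccc1CO` reaches only the limit of the assay, > 10000 nM. Compound 2 `CNC[C@]1(O)Cc2ccccc2[C@@H]1Oc1ccccc1Cl` gives 10000 nM in this assay. Compound 3 `CNC[C@]1(O)Cc2ccccc2[C@@H]1Oc1c(C)cccc1F` again sits at the limit, > 10000 nM, so for it only a bound is known and no number. For the measured compounds named here, the one step that can be read, a number no higher from compound 1 to compound 2 (the limit leaves the size open), is itself open in size, and the limit of > 10000 nM in this assay, at which 2 of the 3 values shown sit, shows that two of the three values are bounds rather than numbers. Compound 3 therefore stands on the weak side of everything measured, with no ordering possible against compound 1 and no resolvable gap to compound 2.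

Compound 4 `CNC[C@]1(O)Cc2ccccc2[C@@H]1Oc1ccccc1F` differs from compound 3 by hydrogen in place of methyl on an aromatic carbon. Going by the values given here, no measured step involves a methyl group, and the only step known, from a hydroxymethyl to a chloro group, carries no size. Nothing in the series suggests that removing the methyl would move this assay beyond the scatter, so the expectation for compound 4 is a value around the limit again, 10000 nM within 3000 nM to 30000 nM, meaning an expected step of a number no higher from compound 3 to compound 4 (the limit leaves the size open).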

Compound 4, half-maximal inhibitory concentration: 4000 nM
The estimate for compound 4 lay 2.5-fold (0.40 log units) above the measured number; the measured number falls inside the stated range.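

In this assay, this position now yields a step of readable size, as fluoro in place of chloro on an aromatic carbon gives a 2.5-fold lower number from compound 2 to compound 4 (0.40 log units; beyond the scatter). For the compounds shown here, with the fluoro group held constant, hydrogen in place of methyl on the aromatic carbon ortho to a large group gives an at least 2.5-fold lower number from compound 3 to compound 4 (0.39 log units; beyond the scatter), so this methyl change is not silent on this read-out, which the earlier compounds could not show. Fluoro in place of hydroxymethyl gives an at least 2.5-fold lower number from compound 1 to compound 4 (0.39 log units; beyond the scatter), which makes compound 4 the strongest of the four, although the steps from compound 1 and compound 3 are open in size and give only a minimum: the limit of > 10000 nM in this assay, at which 2 of the 4 values shown sit.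

The compounds shown leave open how a bromo, methoxy or nitrile group would read at this place on the aryl ether ring. They also leave open whether a methyl group added to the chloro ring of compound 2 would act as it does on the fluoro ring.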